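Amine replacement on the shared core: expectation for compound 3

The source may report more compounds than this note shows. Statements on the series, on what has been measured and on what is new or still open speak of the compounds shown alone.

Of the compounds shown here, two sharing the amide-linked core have been measured. Compound 1 `O=C(CCc1ccc(C(F)(F)F)cc1)Nc1ccc2nc(N3CC4CC3CN4)ccc2c1` gives 210 nM in an assay on isolated protein for displacement of a labelled ligand from melanin-concentrating hormone receptor 1 (Homo sapiens); on this read-out lower numbers stand for stronger inhibition and higher numbers for weaker inhibition. Within the data shown here, compound 2 `CNC(=O)NC1CCN(c2ccc3cc(NC(=O)CCc4ccc(C(F)(F)F)cc4)ccc3n2)C1` gives 6 nM in this assay, and the single step of a 35-fold lower number from compound 1 to compound 2 (1.54 log units; beyond the scatter) shows that exchanging the group on the aromatic carbon of the ring with one nitrogen moves the number a long way. Compound 2 therefore stands lowest of the two numbers, with compound 1 the nearest and well beyond the scatter.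

Compound 3 `CCN(CC)c1ccc2cc(NC(=O)CCc3ccc(C(F)(F)F)cc3)ccc2n1` has not been measured. It differs from compound 2 by diethylamino in place of 3-((methylcarbamoyl)amino)pyrrolidin-1-yl on an aromatic carbon; the place is the same aromatic carbon, next to the ring nitrogen, at which the measured step was taken. That step bears directly on the change, and it was large; the group entering in compound 3 carries no hydrogen-bond donor, unlike either measured group at this position. A shift back toward, or past, compound 1 is expected rather than a change within the scatter. For compound 3 the estimate in this assay is 120 nM, within 30 nM to 500 nM. This corresponds to an expected step of a 20-fold higher number from compound 2 to compound 3 (1.30 log units; beyond the scatter).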

Compound 3, half-maximal inhibitory concentration: 88 nM
Estimate against measurement, compound 3: 1.4-fold (0.13 log units) above; the range from low to high includes it.
By their numbers in this assay, from the lowest: compound 2; then compound 3; then compound 1.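

Notes on the position: in this assay, diethylamino in place of 3-((methylcarbamoyl)amino)pyrrolidin-1-yl gives a 15-fold higher number from compound 2 to compound 3 (1.17 log units; beyond the scatter), so the low number of compound 2 does not carry over to a smaller open-chain amine at this aromatic carbon next to the ring nitrogen. The other new step, a 2.4-fold lower number from compound 1 to compound 3 (0.38 log units; beyond the scatter), shows that a group with no ring can still stand below the group with two five-membered non-aromatic rings, so a ring at this place is not required to get under the number of compound 1, and group size alone does not order the three compounds, with compound 1, carrying the mid-sized group, going against any such trend. No measured evidence is available here to explain either step.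

From the compounds shown here alone, what remains open is how much of the gain in compound 2 belongs to the pyrrolidine ring and how much to the methylurea on it. A plain pyrrolidin-1-yl or a 3-aminopyrrolidin-1-yl at this carbon would separate the two, and an acetamide on the same ring would test whether the urea nitrogen with its methyl group is needed.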